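The source may report more compounds than this note shows. Statements on the series, on what has been measured and on what is new or still open speak of the compounds shown alone.

The measured compounds in a functional assay on QGY7701 cells (Homo sapiens) for cytotoxicity, read by MTT assay, with a stated time of 24 h; a lower number here means a stronger inhibitor, a higher number a weaker inhibitor:
Compound 1 `C=CC1=C(C(=O)NC2CCCCC2)C(c2ccc(OC)cc2)OC1` reaches only the limit of the assay, > 100000 nM.
Compound 2 `C=CC1=C(C(=O)Nc2ccccc2OC)C(c2ccc(Cl)c(Cl)c2)OC1` likewise reaches only the limit, > 100000 nM.
Compound 3 `C=CC1=C(C(=O)NC2CCCCC2)C(c2ccc(F)cc2)OC1` gives 40500 nM.

Compound 1 stands at the limit of this assay rather than at a number, so only a bound is known for it, and compound 2 shares that bound, as the limit of > 100000 nM in this assay, at which 2 of the 3 values shown sit, records. Going by the values given here, the one step that has been measured runs from compound 1 to compound 3, a fluoro in place of methoxy on an aromatic carbon, and it gave an at least 2.4-fold lower number from compound 1 to compound 3 (0.39 log units; beyond the scatter); that step at least reaches beyond the scatter, but it touches the aromatic ring, not the amide nitrogen.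

Compound 4 `C=CC1=C(C(=O)NCC(C)C)C(c2ccc(OC)cc2)OC1` differs from compound 1 in another place: isobutyl in place of cyclohexyl on an amide-type nitrogen. No measured step changes this part of the shared core, so nothing shown bears directly on the move from cyclohexyl to isobutyl. Given that compound 1 sits at > 100000 nM, the expectation is that compound 4 also stays weak, with the step that the limit leaves unreadable from compound 1 to compound 4 expected to lie within the scatter. Compound 4 is therefore estimated at 150000 nM, in the range 40000 nM to 600000 nM, with a fair chance that this assay again reports only a limit.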

Compound 4, half-maximal inhibitory concentration: > 100000 nM
Compound 4: only a limit was reported (the forecaster's own chance of this, stated with the estimate: 65%); the middle value does not contradict the limit.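

Compound 4 and compound 1 both stop at the limit of this assay, so no size can be read for the change from cyclohexyl to isobutyl on the amide-type nitrogen: the limit of > 100000 nM in this assay, at which 3 of the 4 values shown sit.

What the compounds shown leave open is whether that amide-nitrogen group matters at all for cytotoxicity once the number rises clear of the limit.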